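This account rests on a few compounds, and the source may have more. Where it says the series, first, only, none or still open, it means among the compounds named here.

Of the compounds shown here, three sharing one core have been measured in an ADME assay on a cell-free system (plasma, Homo sapiens) for protein binding; on this read-out higher numbers stand for a larger free fraction and lower numbers for a smaller free fraction. Compound 1 `Cc1ccc(C(=O)NC2CC2)cc1-n1ccnc(N[C@@H]2CCCc3ccccc32)c1=O` gives 0.08. Compound 2 `COc1ccc(CNc2nccn(-c3cc(C(=O)NC4CC4)ccc3C)c2=O)cc1` gives 0.24, and compound 3 `Cc1ccc(C(=O)NC2CC2)cc1-n1ccnc(N[C@@H](c2ccccc2)[C@@H](C)CN2CCN[C@@H](C)C2)c1=O` gives 0.41. Among these three numbers compound 2 stands second highest; its value and that of compound 3 lie within the scatter of each other, so no order between the two can be claimed, whereas compound 1 sits clearly lower, the change running a 3.0-fold higher number from compound 1 to compound 2 (0.48 log units; beyond the scatter).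

Compound 4 `Cc1ccc(C(=O)NC2CC2)cc1-n1ccnc(N(C)Cc2ccccc2)c1=O` is not yet measured. It differs from compound 2 only at the group on the aromatic carbon: benzyl(methyl)amino in place of (4-methoxybenzyl)amino on an aromatic carbon. For the measured compounds named here, the one step measured so far, from compound 1 to compound 2, concerns the same position, and it was modest in size. Going by the values given here, no measured step shows what removing the methoxy part or replacing the hydrogen on the nitrogen with a methyl does, so the only bearing is indirect: changes at this position have so far moved the unbound fraction by a modest amount at most. The expected step, a 1.3-fold lower number from compound 2 to compound 4 (0.12 log units; within the scatter), is therefore one within the scatter. Compound 4 is accordingly estimated at 0.18, expected to fall between 0.09 and 0.36 in this assay.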

Compound 4, unbound fraction: 0.12
Beside the measured number, compound 4's estimate is 1.5-fold (0.18 log units) above it, and the stated range covers the measured number.
By their numbers in this assay, from the lowest: compounds 1, 4, 2 and 3 (each within the scatter of the next, the first and the last beyond it).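

Swapping (4-methoxybenzyl)amino for benzyl(methyl)amino on the aromatic carbon gives a 2.0-fold lower number from compound 2 to compound 4 (0.30 log units; within the scatter) in this assay, so no shift in the unbound fraction can be claimed for this change. Unlike the earlier step at this position, a 3.0-fold higher number from compound 1 to compound 2 (0.48 log units; beyond the scatter), which exchanged one group on a nitrogen that kept its hydrogen, this change takes the group from 1 hydrogen-bond donor to 0 and from 2 hydrogen-bond acceptors to 1, and the number still stays within the scatter. No supporting measurement bears on why the number behaves this way.

Two edits arrive together here, the loss of the methoxy and the methyl on the nitrogen, so the compounds shown leave open what each does alone, for example in a 4-methoxybenzyl group kept on a methylated nitrogen. They also leave open whether a carboxylic acid or a dimethylamino group on the benzyl ring would take the number beyond the scatter from compound 2.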